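Solubility of a morpholinylmethyl analogue of compound 2

The source may report more compounds than this note shows. Statements on the series, on what has been measured and on what is new or still open speak of the compounds shown alone.

Measured so far:
compound 1, `CNC(=O)c1cc(C(=O)NC2CCC2)cn(Cc2cccc(NC)c2)c1=O`: >= 155 ug/mL
compound 2, `CNC(=O)c1cc(C(=O)NCCC2CCOCC2)cn(Cc2ccccc2)c1=O`: >= 127 ug/mL

The account follows a physicochemical assay for solubility (on this read-out lower numbers stand for lower solubility and higher numbers for higher solubility), across two measured compounds and one that is yet to be measured. Compound 2, `CNC(=O)c1cc(C(=O)NCCC2CCOCC2)cn(Cc2ccccc2)c1=O`, gives only a limit of the assay in this assay, >= 127 ug/mL, and not a number. Compound 1, `CNC(=O)c1cc(C(=O)NC2CCC2)cn(Cc2cccc(NC)c2)c1=O`, likewise gives only a limit, >= 155 ug/mL. Going by the values given here, both values shown are therefore limits, so compound 2 stands at the limit of >= 127 ug/mL in this assay, at which 1 of the 2 values shown sits, without a measured number to compare against, and no step between measured compounds can be drawn.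

Compound 3, `CNC(=O)c1cc(C(=O)NCCCC2CNCCO2)cn(Cc2ccccc2)c1=O`, has not yet been measured. It differs from compound 2 by (morpholin-2-yl)methyl in place of oxan-4-yl on a saturated chain carbon, two bonds along the chain from an amide-type nitrogen. With no measured step to lean on, the expectation for compound 3 rests on the fact that both shown values are limits at the high end of this assay. Compound 3 is therefore expected to remain readily soluble, most likely again reported as a limit, with an expected step that the limit leaves unreadable from compound 2 to compound 3 that is not expected to exceed the scatter. The estimate for compound 3 in this assay is 150 ug/mL, within a range from 80 ug/mL to 300 ug/mL.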

Compound 3, solubility: >= 194 ug/mL
Compound 3: no number, only a limit (the forecaster's own chance of this, stated with the estimate: 70%); at least 1.2-fold (0.11 log units) between middle value and limit.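

In this assay compound 3 gives >= 194 ug/mL, which is a limit and not a number. Going by these compounds alone, compound 2 also gives only a limit, >= 127 ug/mL, so no step between compound 2 and compound 3 can be read. The compounds shown leave open how soluble each one really is, and whether (morpholin-2-yl)methyl in place of oxan-4-yl changes solubility at all.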